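Imidazopyrazine benzimidazoles: from compound 3 to compound 4

This account rests on a few compounds, and the source may have more. Where it says the series, first, only, none or still open, it means among the compounds named here.

Compound 1 `c1ccc(-c2cn3ccnc3c(-c3ccc4ncn(C5CCCCC5)c4c3)n2)cc1` gives 55.2% in a functional assay on UO-31 cells (Homo sapiens) for inhibition, read by sulforhodamine B assay, with a stated time of 48 h, tested at 10 uM; on this read-out higher numbers stand for more inhibition at the one concentration tested (going by the name of the read-out) and lower numbers for less inhibition.
Compound 2 `Brc1ccc(-c2cn3ccnc3c(-c3ccc4ncn(C5CCCCC5)c4c3)n2)cc1` gives 42.9% in this assay.
Compound 3 `COc1ccccc1-c1cn2ccnc2c(-c2ccc3ncn(C4CCCCC4)c3c2)n1` gives 24% in this assay.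

Compound 3 stands lowest of the three numbers in this assay, with compound 2 nearest and compound 1 furthest. Compound 4 `FC(F)(F)c1cccc(-c2cn3ccnc3c(-c3ccc4ncn(C5CCCCC5)c4c3)n2)c1` differs from compound 3 at one place: 3-(trifluoromethyl)phenyl in place of 2-methoxyphenyl on an aromatic carbon. The step most comparable is the aryl swap a number 18.9 percentage points lower from compound 2 to compound 3 (beyond the scatter); the substituent steps a number 12.3 percentage points lower from compound 1 to compound 2 (beyond the scatter) and a number 31.2 percentage points lower from compound 1 to compound 3 (beyond the scatter) show that both groups on the phenyl ring lowered the number from the unsubstituted compound 1. Among the measured compounds shown here, no measured compound carries trifluoromethyl, so the step is expected to be a modest rise, a number 16 percentage points higher from compound 3 to compound 4 (beyond the scatter), toward the level of compound 2. Compound 4 is therefore estimated at 40%, within 22% to 58%.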

Compound 4, a percentage reported as inhibition, at one concentration (the size of the read-out at that concentration, not a potency): 22.5%
For compound 4 the middle estimate is 17.5 percentage points above the measured one; low and high end bracket the measured number.
By their numbers in this assay, from the lowest: compounds 4 and 3 (each within the scatter of the next); then compound 2; then compound 1.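

In this assay, 3-(trifluoromethyl)phenyl and 2-methoxyphenyl cannot be told apart at this aromatic carbon (a number 1.5 percentage points lower from compound 3 to compound 4 (within the scatter)), although only the leaving group carries a hydrogen-bond acceptor. The trifluoromethyl compound also reads under both the 4-bromophenyl compound (a number 20.4 percentage points lower from compound 2 to compound 4 (beyond the scatter)) and the unsubstituted phenyl compound (a number 32.7 percentage points lower from compound 1 to compound 4 (beyond the scatter)), so all three substituted phenyl compounds now lie beneath compound 1. Nothing available explains these differences. On these data alone, it remains open whether the group or its ring position sets the number, since the three substituted rings differ in both. As far as these compounds go, how a phenyl ring bearing an amine or a carboxylic acid would read also remains open.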